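A few compounds are considered here, and "the series" means these few. Any claim that something is new, unique, unknown or untested is made for them only; others in the source may bear on it.

Working notes on the series. Compound 3 `COc1ccc(-c2cc3ccccc3nc2/C=C/C(=O)c2ccccn2)cc1` stands second highest of the three numbers in a functional assay on MCF7 cells (Homo sapiens) for antiproliferative activity, read by XTT assay, with a stated time of 72 h (a higher number here means a weaker inhibitor, a lower number a stronger inhibitor), where compound 3 gives 810 nM; compound 1 `COc1ccc(-c2cc3ccccc3nc2/C=C/C(=O)c2ccco2)cc1` gives 710 nM and compound 2 `COc1ccc(-c2cc3ccccc3nc2/C=C/C(=O)c2cccs2)cc1` gives 1030 nM, all three within the scatter of one another. Compound 4 `COc1ccc(-c2cc3ccccc3nc2/C=C/C(=O)c2c[nH]c3ccccc23)cc1` differs from compound 3 by 1H-indol-3-yl in place of pyridin-2-yl on a carbonyl carbon. Within the data shown here, the steps that bear on it are the earlier swaps at the same place: a 1.5-fold higher number from compound 1 to compound 2 (0.16 log units; within the scatter), a 1.1-fold higher number from compound 1 to compound 3 (0.06 log units; within the scatter) and a 1.3-fold lower number from compound 2 to compound 3 (0.10 log units; within the scatter), none beyond the scatter. None of them brings in a group as large as 1H-indol-3-yl, so no direction can be read; the expected change is a 1.0-fold lower number from compound 3 to compound 4 (0.01 log units; within the scatter), not beyond the scatter. Compound 4 is therefore estimated at 800 nM, with a range from 300 nM to 2500 nM.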

Compound 4, half-maximal inhibitory concentration: > 10000 nM
Compound 4 ended at the assay's limit (the forecaster's own chance of this, stated with the estimate: 5%); at least 12-fold (1.09 log units) between middle value and limit.
By their numbers in this assay, from the lowest: compounds 1, 3 and 2 (each within the scatter of the next). At a limit, above all of these: compound 4.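

In this assay, the place on the carbonyl carbon, where furan-2-yl, thiophen-2-yl and pyridin-2-yl stay within the scatter of one another, proves sensitive to the group it carries: an at least 12-fold higher number from compound 3 to compound 4 (1.09 log units; beyond the scatter), an at least 9.7-fold higher number from compound 2 to compound 4 (0.98 log units; beyond the scatter) and an at least 14-fold higher number from compound 1 to compound 4 (1.14 log units; beyond the scatter). The value of compound 4 is a limit of the assay, not a number: the limit of > 10000 nM in this assay, at which 1 of the 4 values shown sits. Compared with pyridin-2-yl, 1H-indol-3-yl brings more heavy atoms and a hydrogen-bond donor, and compound 4 changes both together.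

Which of the two matters remains open. Naphthalen-2-yl or 1-methyl-1H-indol-3-yl at this place would separate them.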